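Swapping ethoxy for a sulfur group at a limit

A few compounds are considered here, and "the series" means these few. Any claim that something is new, unique, unknown or untested is made for them only; others in the source may bear on it.

Measured so far in an in vitro ADME assay on microsomes from liver (Simiiformes); on this read-out higher numbers stand for a longer-lived compound and lower numbers for a shorter-lived compound (the half-life of each compound):
- compound 1 `CCOCc1cc(CCCOc2c(C)cc(-c3noc(C(F)(F)F)n3)cc2C)on1` gives > 2.5 h (a limit)
- compound 2 `CCc1cc(CCCOc2c(C)cc(-c3noc(C4CC4)n3)cc2C)on1` gives 0.9 h
- compound 3 `COCc1cc(CCCOc2c(C)cc(-c3noc(C4CC4)n3)cc2C)on1` gives > 2.5 h (a limit)

Compound 1 gives > 2.5 h in this assay and this is a limit, not a number. Its place on the scale is therefore the limit of > 2.5 h in this assay, at which 2 of the 3 values shown sit, and its true half-life is not known.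

Compound 4 `Cc1cc(-c2noc(C(F)(F)F)n2)cc(C)c1OCCCc1cc(C[S+](C)[O-])no1` has not yet been measured. It keeps the core of compound 1 and changes in one place only: a group of 3 heavy atoms (1 carbon, 1 oxygen, 1 sulfur; no ring) in place of a group of 3 heavy atoms (2 carbon, 1 oxygen; no ring), on a saturated chain carbon bound to an aromatic carbon and ethoxy is the group that leaves.

Going by the values given here, only one measured step touches this kind of place. That step is an at least 2.7-fold higher number from compound 2 to compound 3 (0.44 log units; beyond the scatter) and it lies beyond the scatter. Going by these compounds, it swaps a different pair of groups, however, and it ends at a limit, so its full size stays unknown. Among the compounds with values here, no measured step involves a sulfur group, which leaves the estimate loose.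

In this assay no step beyond the scatter is expected, and the estimated step is a number no higher from compound 1 to compound 4 (the limit leaves the size open) in size. The estimated half-life of compound 4 is 2.5 h with an expected range from 1 h to 5 h and the assay may again report only a limit.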

Compound 4, half-life: > 2.5 h
Compound 4 ended at the assay's limit; the forecaster's own chance of this, stated with the estimate: 55%; the middle value sits exactly at the limit.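

In this assay compound 4 gives > 2.5 h, which is a limit of the assay. Compound 1 gives > 2.5 h, also a limit. Going by these compounds alone, with two limits, no step between compound 1 and compound 4 can be read. The compounds shown leave open whether the sulfur group in place of ethoxy changes the half-life at all, and the values give little room to tell: the limit of > 2.5 h in this assay, at which 3 of the 4 values shown sit.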